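Chloro to trifluoromethyl on the benzyl sulfonyl group

The compounds below may be only part of what the source reports. "The series", "measured", "known", "first", "only" and "open" are said of these compounds alone.

Measured in a functional assay (Platelet, plasma) for inhibition, with Homo sapiens as the target (a lower number here means a stronger inhibitor, a higher number a weaker inhibitor), so far:
compound 1 `N#Cc1cc2c(nc1N1CCC(C(=O)NS(=O)(=O)Cc3ccccc3F)CC1)COC2=O` gives 23700 nM
compound 2 `N#Cc1cc2c(nc1N1CCC(C(=O)NS(=O)(=O)Cc3ccc(Cl)cc3)CC1)COC2=O` gives 4420 nM

Compound 2 at 4420 nM holds the lower of the two numbers in this assay and stands clear of compound 1. The next step leads to compound 3 `N#Cc1cc2c(nc1N1CCC(C(=O)NS(=O)(=O)Cc3ccc(C(F)(F)F)cc3)CC1)COC2=O` (trifluoromethyl in place of chloro on an aromatic carbon): trifluoromethyl in place of chloro on an aromatic carbon, para to a large group, so that 4-chlorobenzyl becomes 4-(trifluoromethyl)benzyl.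

Going by the values given here, one measured step bears on this change. The move to 4-chlorophenyl from 2-fluorophenyl gave a 5.4-fold lower number from compound 1 to compound 2 (0.73 log units; beyond the scatter) and was modest, though beyond the scatter. That step altered both the substituent and its place, whereas here the place stays the same. Among the compounds with values here, the series holds no measured trifluoromethyl example, so neither direction is favoured, and no step beyond the scatter is expected. The estimated step is a 1.0-fold higher number from compound 2 to compound 3 (0.01 log units; within the scatter) with a wide margin on either side. Compound 3 is expected at 4500 nM with an estimated range from 1800 nM to 11000 nM in this series.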

Compound 3, half-maximal inhibitory concentration: 15900 nM
Compound 3: middle estimate off by 3.5-fold (0.55 log units), on the low side; measured number above the stated range.
By their numbers in this assay, from the lowest: compound 2; then compounds 3 and 1 (each within the scatter of the next).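

In this assay, the group on this aromatic carbon, para to a large group, matters in its own right: with the place held fixed, trifluoromethyl in place of chloro gives a 3.6-fold higher number from compound 2 to compound 3 (0.56 log units; beyond the scatter). The lower number of compound 2 therefore does not carry over to every group at this place, since a 1.5-fold lower number from compound 1 to compound 3 (0.17 log units; within the scatter), which leaves 4-(trifluoromethyl)phenyl and 2-fluorophenyl within the scatter of each other. No supporting measurement is available to explain the difference between chloro and trifluoromethyl here.

The compounds shown leave open whether chloro is a singular case at this place or one of several groups that give a number like that of compound 2, and a bromo, methyl or methoxy group there would test this directly. They also leave open how much of the step from 2-fluorophenyl to 4-chlorophenyl belongs to the place and how much to the group, a question that 4-fluorophenyl, or 2-chlorophenyl, on the same sulfonyl chain carbon would separate.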